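Chloro in Place of Hydrogen Across Two Amide Cores

This account rests on a few compounds, and the source may have more. Where it says the series, first, only, none or still open, it means among the compounds named here.

Compound 1 `Cc1cc(-c2nc3ccccc3o2)ccc1NC(=O)CCl` and compound 2 `Cc1cc(-c2nc3cc(Cl)ccc3o2)ccc1NC(=O)CCl` share one core and differ in a single place: compound 2 carries chloro in place of hydrogen on an aromatic carbon. In a functional assay on HepG2 cells (Homo sapiens) for cytotoxicity, read by MTT assay, with a stated time of 24 h (on this read-out lower numbers stand for stronger inhibition and higher numbers for weaker inhibition), compound 1 gives 14800 nM, while compound 2 gives 35000 nM, so that a 2.4-fold higher number from compound 1 to compound 2 (0.37 log units; beyond the scatter). Compound 3 `CN(C)CCCN1CCN(CC(=O)Nc2ccc(-c3nc4ccccc4o3)cc2)CC1` is built on a second core; the difference between the two cores is not broken down here. In this assay compound 3 gives 9500 nM, the lowest of the three numbers, though it lies within the scatter of compound 1 and is separated from compound 2 by a gap beyond the scatter.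

Compound 4 `CN(C)CCCN1CCN(CC(=O)Nc2ccc(-c3nc4cc(Cl)ccc4o3)cc2)CC1` has not yet been measured. It stands to compound 3 as compound 2 stands to compound 1, carrying (chloro in place of hydrogen on an aromatic carbon); the place is described in the same words as before, so this is the same change on a different core. Its effect has been seen once among these compounds. For compound 4 in this assay the author expects a 2.1-fold higher number from compound 3 to compound 4 (0.32 log units; beyond the scatter), resting on a 2.4-fold higher number from compound 1 to compound 2 (0.37 log units; beyond the scatter) and on the value of compound 3, with a wider range because a single precedent is thin ground. The expected value for compound 4 is therefore 20000 nM, between 9000 nM and 45000 nM.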

Compound 4, half-maximal inhibitory concentration: 1250 nM
Estimate against measurement, compound 4: 16-fold (1.20 log units) above; the measured number lies below the stated range.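

On the core of compound 3, chloro in place of hydrogen gives a 7.6-fold lower number from compound 3 to compound 4 (0.88 log units; beyond the scatter) in this assay, whereas the same change on the core of compound 1 gives a 2.4-fold higher number from compound 1 to compound 2 (0.37 log units; beyond the scatter). This rests on a single pair for each core, and it does not show which of the differences between the two cores goes with the reversal, nor whether either step would hold for other compounds built on the same core. Set side by side, the two steps show that in this series the effect of the change cannot be carried from one core to the other, in either direction or size: the same change on two cores in this assay, a 2.4-fold higher number (0.37 log units; beyond the scatter) from compound 1 to compound 2 and a 7.6-fold lower number (0.88 log units; beyond the scatter) from compound 3 to compound 4, 18-fold (1.25 log units) apart, beyond the scatter of two such steps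

The compounds shown leave open which part of the core decides the direction of the step, for instance whether the methyl group on the central ring of compound 1 or the chloroacetamide end plays a part. They also leave open whether fluoro, bromo or methoxy on the same aromatic carbon would follow the step seen on either core.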